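Swapping the aryl group on a shared core

The source may report more compounds than this note shows. Statements on the series, on what has been measured and on what is new or still open speak of the compounds shown alone.

Measured in a functional assay on CCRF-CEM cells (Homo sapiens) for antiproliferative activity; a lower number here means a stronger inhibitor, a higher number a weaker inhibitor:
- compound 1 `COc1cc(C(=O)c2sc(-c3ccc(I)cc3)cc2N)cc(OC)c1OC`: 150 nM
- compound 2 `COc1cc(C(=O)c2sc(-c3cccc([N+](=O)[O-])c3)cc2N)cc(OC)c1OC`: 5.9 nM

Of these two numbers in this assay, compound 2 holds the lower, at 5.9 nM. Compound 3 `COc1cc(C(=O)c2sc(-c3ccncc3)cc2N)cc(OC)c1OC` has not yet been measured. It carries pyridin-4-yl in place of 3-nitrophenyl on an aromatic carbon of the five-membered aromatic ring with 1 sulfur, and the rest of the structure stays the same: pyridin-4-yl in place of 3-nitrophenyl on an aromatic carbon.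

Among the compounds with values here, only one measured step bears on this change. At the same carbon, 3-nitrophenyl in place of 4-iodophenyl gave a 25-fold lower number from compound 1 to compound 2 (1.41 log units; beyond the scatter), a large step beyond the scatter. Within the data shown here, the number therefore responds strongly to the group at this place, but no measured compound carries pyridin-4-yl. With compound 2 at the low end of what has been seen, a sizeable step towards a higher number is expected, of about the same order as the measured one or smaller.

The expected change is a 10-fold higher number from compound 2 to compound 3 (1.01 log units; beyond the scatter). Compound 3 is estimated at 60 nM, with an expected range of 10 nM to 400 nM.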

Compound 3, half-maximal inhibitory concentration: 110 nM
Compound 3: the middle estimate sits 1.8-fold (0.26 log units) below what was measured, within the range that was stated.
By their numbers in this assay, from the lowest: compound 2; then compounds 3 and 1 (each within the scatter of the next).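

In this assay, the change from 3-nitrophenyl to pyridin-4-yl on this aromatic carbon next to the ring sulfur gave a 19-fold higher number from compound 2 to compound 3 (1.27 log units; beyond the scatter) and so showed that a second group at this place, smaller than 3-nitrophenyl, does not keep the low number of compound 2. The comparison with the first compound gave a 1.4-fold lower number from compound 1 to compound 3 (0.13 log units; within the scatter) and lies within the scatter, so 4-iodophenyl and pyridin-4-yl cannot be told apart here, although they differ in ring type and in size, and compound 2 stands alone as the most potent of the three, with clear steps to both of the others. No separate measurement bears on what lies behind these steps.

The three groups differ in several ways at once, which leaves open whether the low number of compound 2 belongs to the nitro group itself or to where it sits on the phenyl ring. A 4-nitrophenyl, a 3-aminophenyl or a pyridin-3-yl group at this carbon, or a plain phenyl, would be needed to separate these two readings.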